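A Methyl for a Fluoro on the Central Ring

The source may report more compounds than this note shows. Statements on the series, on what has been measured and on what is new or still open speak of the compounds shown alone.

Compound 1 `NS(=O)(=O)c1ccc(Nc2ncc(F)c(Nc3nc4ccccc4s3)n2)cc1`: > 50000 nM
Compound 2 `NS(=O)(=O)c1ccc(Nc2ncc(F)c(Nc3nc4ccc(Cl)cc4s3)n2)cc1`: 8340 nM
Compound 3 `CS(=O)(=O)c1ccc(Nc2ncc(F)c(Nc3nc4ccc(Cl)cc4s3)n2)cc1`: > 50000 nM

Of the three measured compounds, only compound 2 gives a number in a functional assay on MCF7 cells (Homo sapiens) for antiproliferative activity, read by MTT assay, with a stated time of 48 h (a lower number here means a stronger inhibitor, a higher number a weaker inhibitor), namely 8340 nM. For compound 1 the assay reports only a limit, > 50000 nM. For compound 3 it likewise reports only a limit, > 50000 nM. Both measured steps therefore end at the limit of > 50000 nM in this assay, at which 2 of the 3 values shown sit: an at least 5.9-fold lower number from compound 1 to compound 2 (0.77 log units; beyond the scatter) and an at least 5.9-fold higher number from compound 2 to compound 3 (0.77 log units; beyond the scatter).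

Compound 4 `Cc1cnc(Nc2ccc(S(N)(=O)=O)cc2)nc1Nc1nc2ccc(Cl)cc2s1` differs from compound 2 by methyl in place of fluoro on an aromatic carbon. Neither measured step touches this ring: the first changes a substituent on the fused ring system, the second the amino on the sulfonyl sulfur. Within the data shown here, no measured step thus bears on the change, and the expectation is a step within the usual scatter, with the wider range that a single surviving number allows. In this assay compound 4 is estimated at 10000 nM, expected to fall between 3000 nM and 40000 nM. The expected step is a 1.2-fold higher number from compound 2 to compound 4 (0.08 log units; within the scatter).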

Compound 4, half-maximal inhibitory concentration: 8430 nM
For compound 4 the middle estimate is 1.2-fold (0.07 log units) above the measured one, within the range that was stated.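

In this assay, the position on the six-membered aromatic ring with 2 nitrogen now has a measured change of its own: methyl in place of fluoro gives a 1.0-fold higher number from compound 2 to compound 4 (0.00 log units; within the scatter). Among these compounds, the earlier steps touched only the fused ring system and the sulfonyl sulfur, so this is the first sign that the group at this position can be exchanged without a change beyond the scatter. It is also the only step shown with a number at both ends: the limit of > 50000 nM in this assay, at which 2 of the 4 values shown sit.

The compounds shown leave open how this position responds to an amine, a methoxy group or a longer chain such as propyl. They also leave open whether methyl and fluoro would remain equivalent here in the settings of compound 1 and compound 3, whose values are limits.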